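Moving one methyl group on the aryl ring

A few compounds are considered here, and "the series" means these few. Any claim that something is new, unique, unknown or untested is made for them only; others in the source may bear on it.

For the measured compounds named here, in a functional assay on HeLa cells (Homo sapiens) for antiproliferative activity, read by MTT assay, with a stated time of 72 h (on this read-out higher numbers stand for weaker inhibition and lower numbers for stronger inhibition), compound 2 `COc1cc(-c2nccn2-c2ccc(C)cc2)cc(OC)c1OC` gives 700 nM as the only true number so far. Compound 1 `COc1cc(-c2nccn2CC(C)C)cc(OC)c1OC` stands at > 100000 nM and that entry is a limit of the assay, not a number.

Compound 3 `COc1cc(-c2nccn2-c2cccc(C)c2)cc(OC)c1OC` has the same atoms as compound 2, joined differently, with 3-methylphenyl in place of 4-methylphenyl on an aromatic nitrogen.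

Going by the values given here, only one measured step bears on this change. The step of an at least 140-fold lower number from compound 1 to compound 2 (2.15 log units; beyond the scatter) is large, and it put 4-methylphenyl in place of isobutyl on that same aromatic nitrogen. It shows that the group at this place can matter a great deal, but it swapped a chain for a ring. Here the ring stays and only its methyl moves, so a much smaller step is expected in this assay with a slight tilt toward weaker inhibition. Among the compounds with values here, no measured step yet shows what such a move does.

The expected change is a 2.0-fold higher number from compound 2 to compound 3 (0.30 log units; within the scatter) as a rough estimate. The expected value for compound 3 is 1400 nM with an estimated range from 250 nM to 8000 nM in this measurement.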

Compound 3, half-maximal inhibitory concentration: 1900 nM
For compound 3 the middle estimate is 1.4-fold (0.13 log units) below the measured one; the measured number falls inside the stated range.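

Where the methyl sits on the aryl ring counts in this assay: the move from 4-methylphenyl to 3-methylphenyl gives a 2.7-fold higher number from compound 2 to compound 3 (0.43 log units; beyond the scatter), a modest step but a real one. An aryl ring still stands far ahead of the isobutyl chain on this nitrogen with the methyl in either place, and for the new compound the step is an at least 52-fold lower number from compound 1 to compound 3 (1.72 log units; beyond the scatter). The true size of that step stays unknown, because compound 1 gives a limit of the assay and not a number: the limit of > 100000 nM in this assay, at which 1 of the 3 values shown sits.

Compounds 2 and 3 show only two places for one small group, so a plain phenyl ring with no methyl would be needed to tell whether the methyl helps at all or whether one of these two placements simply costs less. From the compounds shown here alone, it also remains open how this position would respond if a methoxy group, a chlorine atom or an amine took the place of the methyl on the ring.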